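Swapping Hydroxymethyl for Chloro on a Hydrolase Inhibitor

The source may report more compounds than this note shows. Statements on the series, on what has been measured and on what is new or still open speak of the compounds shown alone.

Compound 1, `Cn1nc2c(=O)n(CC3(O)CCN(Cc4ccc(-c5ccco5)cc4Cl)CC3)cnc2c1-c1ccc(CO)cc1`, gives 42.5 nM in an assay on isolated protein for inhibition of ubiquitin carboxyl-terminal hydrolase 7 (Homo sapiens), with stated times of 30 min and 2 h; a lower number here means a stronger inhibitor, a higher number a weaker inhibitor.
Compound 2, `Cn1nc2c(=O)n(CC3(O)CCN(Cc4ccc(-c5ccco5)cc4Cl)CC3)cnc2c1-c1ccc(CNS(C)(=O)=O)cc1`, gives 65.3 nM in this assay.
Compound 3, `Cn1nc2c(=O)n(CC3(O)CCN(Cc4ccc(C5CCCO5)cc4Cl)CC3)cnc2c1-c1ccc(CN)cc1`, gives 3820 nM in this assay.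

Compound 1 has the lowest number of the three, but compound 2 sits within the scatter of it, so the two cannot be ordered; compound 3 lies well beyond, with a far higher number.

The next compound, compound 4, `Cn1nc2c(=O)n(CC3(O)CCN(Cc4ccc(-c5ccco5)cc4Cl)CC3)cnc2c1-c1ccc(Cl)cc1`, differs from compound 1 in one place: chloro in place of hydroxymethyl on an aromatic carbon.

Among the compounds with values here, only one measured step touches the same aryl group: a 1.5-fold higher number from compound 1 to compound 2 (0.19 log units; within the scatter). There the hydroxy group gave way to a methanesulfonamido group and the number hardly moved, which suggests the end of this side chain tolerates change. Within the data shown here, no measured step removes the whole hydroxymethyl group or places a chloro there, and compound 3 differs from compound 1 in several places at once, so its high number cannot be tied to this position.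

On that basis the change to chloro is expected to cost little, with a 1.5-fold higher number from compound 1 to compound 4 (0.18 log units; within the scatter) as the estimated step. Compound 4 is therefore expected to give about 65 nM in this assay, likely between 22 nM and 200 nM.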

Compound 4, half-maximal inhibitory concentration: 143 nM
Estimate against measurement, compound 4: 2.2-fold (0.34 log units) below; low and high end bracket the measured number.
By their numbers in this assay, from the lowest: compounds 1 and 2 (each within the scatter of the next); then compound 4; then compound 3.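

In this assay, within the data shown here, this position proves less forgiving than the earlier compounds suggested: chloro in place of hydroxymethyl gives a 3.4-fold higher number from compound 1 to compound 4 (0.53 log units; beyond the scatter) as a modest change that still lies clear of the scatter. Changing only the end of the side chain gave a 1.5-fold higher number from compound 1 to compound 2 (0.19 log units; within the scatter) while replacing the whole (methanesulfonamido)methyl group with chloro gave a 2.2-fold higher number from compound 2 to compound 4 (0.34 log units; beyond the scatter) as well, so among these three compounds the end of the side chain can change with little effect, but losing the whole group costs something. Hydroxymethyl carries a hydrogen-bond donor and a hydrogen-bond acceptor and chloro carries neither, yet no measurement available here links that difference to the higher number or offers any other explanation.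

The compounds shown leave open whether the higher number comes from the presence of chloro or from the absence of a side chain, a question that a plain hydrogen or a methyl group on this aromatic carbon could help answer. They also leave open how a carboxylic acid or a longer chain ending in hydroxy would behave here.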